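The compounds below may be only part of what the source reports. "The series", "measured", "known", "first", "only" and "open" are said of these compounds alone.

Measured compounds:
Compound 1, `Cc1c(Nc2nc(N)c3c(C#N)c(N4CCC[C@H]4C)n(C)c3n2)cnn1[C@H]1CCOC1`: in an assay on HEK293 cells for inhibition of Leucine-rich repeat serine/threonine-protein kinase 2 (Homo sapiens), with a stated time of 48 h (on this read-out higher numbers stand for weaker inhibition and lower numbers for stronger inhibition), compound 1 gives 140 nM.
Compound 2, `Cc1nn(CC(C)(C)O)cc1Nc1nc(N)c2c(C#N)c(N3CCC[C@H]3C)n(C)c2n1`: in this assay compound 2 gives 280 nM.

Going by the values given here, compound 2 has the higher of these two numbers, but its only neighbour, compound 1, lies within the usual scatter of it, so no order between the two can be claimed. Compound 3, `Cc1nn(C)cc1Nc1nc(N)c2c(C#N)c(N3CCC[C@H]3C)n(C)c2n1`, differs from compound 2 in a single place: hydrogen in place of 1-hydroxy-1-methylethyl on a saturated chain carbon bound to an aromatic nitrogen. Among the compounds with values here, no measured pair differs in just this way, so the size of the step must be guessed from the two compounds at hand, both of which carry a group of several heavy atoms on that aromatic nitrogen and give similar numbers. The expected step from compound 2 to compound 3 in this assay is a 1.4-fold higher number from compound 2 to compound 3 (0.15 log units; within the scatter), a small move toward higher numbers, around the edge of the scatter. Compound 3 is therefore estimated at 400 nM, with a range from 130 nM to 1200 nM.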

Compound 3, half-maximal inhibitory concentration: 190 nM
Compound 3: middle estimate off by 2.1-fold (0.32 log units), on the high side; measured number inside the range.
By their numbers in this assay, from the lowest: compounds 1, 3 and 2 (each within the scatter of the next).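

Until now, both compounds carried a group of several heavy atoms on the aromatic nitrogen, so it could not be told whether this position needs such a group. In this assay, cutting 2-hydroxy-2-methylpropyl back to methyl gives a 1.5-fold lower number from compound 2 to compound 3 (0.17 log units; within the scatter), so losing 1-hydroxy-1-methylethyl, with its hydrogen-bond donor and acceptor, produces no difference that can be told from the scatter, and this read-out does not depend measurably on that group in this pair. Nothing at hand gives a reason for this result.

What the compounds shown leave open is whether any group on this saturated chain carbon can move the number beyond the scatter. An amine, a carboxylic acid or a longer chain there could answer that, and the three compounds give no hint which way such a group would go.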